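The compounds below may be only part of what the source reports. "The series", "measured", "known", "first", "only" and "open" are said of these compounds alone.

Working notes on the series. In a functional assay on HeLa cells (Homo sapiens) for antiproliferative activity, read by MTT assay, with a stated time of 3 days (on this read-out higher numbers stand for weaker inhibition and lower numbers for stronger inhibition), compound 3 `CCCCCC#Cc1cn(C/C=C/CN2C(=O)c3ccccc3C2=O)c(=O)[nH]c1=O` gives 91000 nM, the highest of the two numbers obtained; compound 1 `CCCCCCC#Cc1cn(C/C=C/CN2C(=O)c3ccccc3C2=O)c(=O)[nH]c1=O` gives 34000 nM and stands nearest, the step between them being a 2.7-fold higher number from compound 1 to compound 3 (0.43 log units; beyond the scatter). Compound 2 `CCCCCCCCC#Cc1cn(C/C=C/CN2C(=O)c3ccccc3C2=O)c(=O)[nH]c1=O` returns only a limit in this assay, > 100000 nM. Lengthening the chain beyond compound 1 yields an at least 2.9-fold higher number from compound 1 to compound 2 (0.46 log units; beyond the scatter), and the comparison an at least 1.0-fold lower number from compound 2 to compound 3 (0.04 log units; that floor lies within the scatter) rests on that limit.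

Compound 4 `CCCCCc1ccc(C#Cc2cn(C/C=C/CN3C(=O)c4ccccc4C3=O)c(=O)[nH]c2=O)cc1` differs from compound 3 by 4-pentylphenyl in place of pentyl on a triple-bonded carbon. For the measured compounds named here, no measured step swaps a chain for a ring; each of them only alters the length of the saturated chain on the triple-bonded carbon. Those steps show that adding carbon at that position can lower the number, as in a 2.7-fold higher number from compound 1 to compound 3 (0.43 log units; beyond the scatter) read backwards, and also raise it, as in an at least 2.9-fold higher number from compound 1 to compound 2 (0.46 log units; beyond the scatter), so the bearing on an aromatic replacement is weak. The expectation for compound 4 is a number near 30000 nM, within 7000 nM to 100000 nM, an expected step of a 3.0-fold lower number from compound 3 to compound 4 (0.48 log units; beyond the scatter).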

Compound 4, half-maximal inhibitory concentration: 27000 nM
Beside the measured number, compound 4's estimate is 1.1-fold (0.05 log units) above it; the range from low to high includes it.
By their numbers in this assay, from the lowest: compounds 4 and 1 (each within the scatter of the next); then compound 3. At a limit, above all of these: compound 2.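

Changing the group on the triple-bonded carbon from a saturated chain to 4-pentylphenyl leaves a measurable number in this assay, giving a 3.4-fold lower number from compound 3 to compound 4 (0.53 log units; beyond the scatter) and, as a floor only, an at least 3.7-fold lower number from compound 2 to compound 4 (0.56 log units; beyond the scatter). Set against the hexyl of compound 1, the aromatic group gives a 1.3-fold lower number from compound 1 to compound 4 (0.10 log units; within the scatter), so at this place the ring-bearing group cannot be told apart from the best saturated chain shown. Compound 2 stands at a limit: the limit of > 100000 nM in this assay, at which 1 of the 4 values shown sits.

Open, going by these compounds, is whether the ring or the pentyl on it governs the number of compound 4, a question that plain phenyl would address. Also open, on these data alone, is how a ring carrying an amine or a carboxylic acid in place of pentyl would read in this assay.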